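Solubility notes: pyrimidine, pyrazine, imidazole and thiophene methylamines

The source may report more compounds than this note shows. Statements on the series, on what has been measured and on what is new or still open speak of the compounds shown alone.

Measured so far:
compound 1 `Cc1cc(NCc2ncccn2)n2nc(C)c(-c3ccccc3)c2n1`, 37900 nM in a physicochemical assay for solubility, read by HPLC, using the shake flask method, measured as kinetic solubility, with a stated time of 2 h, at pH 7.4; a lower number here means a less soluble compound, a higher number a more soluble compound
compound 2 `Cc1cc(NCc2cnccn2)n2nc(C)c(-c3ccccc3)c2n1`, 7100 nM in this assay
compound 3 `Cc1cc(NCc2ncc[nH]2)n2nc(C)c(-c3ccccc3)c2n1`, < 5000 nM in this assay

Compound 3 stands at the bottom of the three. Its reading in this assay is a limit of the assay, not a number (the limit of < 5000 nM in this assay, at which 1 of the 3 values shown sits), so its true position is open below that line. The two measured steps leading down to it are an at least 7.5-fold lower number from compound 1 to compound 3 (0.87 log units; beyond the scatter) and an at least 1.4-fold lower number from compound 2 to compound 3 (0.15 log units; that floor lies within the scatter); the first is beyond the scatter, the second only a floor that lies within it. The parallel change a 5.3-fold lower number from compound 1 to compound 2 (0.73 log units; beyond the scatter) shows the same direction.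

The next compound, compound 4 `Cc1cc(NCc2cccs2)n2nc(C)c(-c3ccccc3)c2n1`, differs from compound 3 by thiophen-2-yl in place of 1H-imidazol-2-yl on a saturated chain carbon bound to a nitrogen on an aromatic ring. Among the compounds with values here, no measured step involves a thiophen-2-yl group here, so the step cannot be read directly from the series; what the measured steps show is that every change away from pyrimidin-2-yl has lowered the number, and compound 3 already sits at the limit.

The working expectation is therefore that compound 4 stays near the low end of this assay, with a step that the limit leaves unreadable from compound 3 to compound 4 expected to be no clear move beyond the scatter. Compound 4 is estimated at 3000 nM, within 700 nM to 12000 nM, with a real chance that the assay again reports only a limit.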

Compound 4, solubility: < 5000 nM
Compound 4 ended at the assay's limit; the forecaster's own chance of this, stated with the estimate: 55%; the middle value lies beyond the limit too.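

Compound 4 is a second reading at the limit of this assay: the limit of < 5000 nM in this assay, at which 2 of the 4 values shown sit.

At the saturated chain carbon bound to a nitrogen on an aromatic ring, thiophen-2-yl now joins pyrazin-2-yl and 1H-imidazol-2-yl as a replacement for pyrimidin-2-yl that gives a lower number, and none of the compounds shown goes against this. Against compound 1 the change is clear, with an at least 7.5-fold lower number from compound 1 to compound 4 (0.87 log units; beyond the scatter), whereas the comparison with the pyrazine, an at least 1.4-fold lower number from compound 2 to compound 4 (0.15 log units; that floor lies within the scatter), gives only a floor and sets no order. The step from compound 3 to compound 4 cannot be read, so replacing 1H-imidazol-2-yl, with its hydrogen-bond donor, by thiophen-2-yl, with none, has no measurable consequence in this series.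

As far as these compounds go, how far compound 3 and compound 4 lie under the limit, and whether they differ from each other, remains open. Also open, from the compounds shown here alone, is whether a pyridin-2-yl or phenyl group at this place would stay near compound 1 or fall to the limit as well.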